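Chain length and the thioamide-bearing arm: compound 2 to compound 3

This account rests on a few compounds, and the source may have more. Where it says the series, first, only, none or still open, it means among the compounds named here.

Two compounds in the series have been run in a functional assay on the whole organism (stomach) with Rattus norvegicus as the target (on this read-out lower numbers stand for an effect already at smaller amounts and higher numbers for an effect only at larger amounts of compound), so far. Compound 1, `N=C(S)CCn1nc(-c2ccc(Cl)cc2)ccc1=O`, gives in this assay > 100 mg/kg, which is a limit of the assay and not a number. Compound 2, `N=C(S)CCCCN1N=C(c2ccccc2)CCC1=O`, gives in this assay 100 mg/kg; this is the only number shown. For the measured compounds named here, since the other value in the set is not a number, there is no measured step to lean on (the limit of > 100 mg/kg in this assay, at which 1 of the 2 values shown sits).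

Compound 3, `N=C(S)CCCN1N=C(c2ccccc2)CCC1=O`, is not yet measured. It differs from compound 2 by a group of 3 heavy atoms (1 carbon, 1 nitrogen, 1 sulfur; no ring) in place of a group of 4 heavy atoms (2 carbon, 1 nitrogen, 1 sulfur; no ring), on a saturated chain carbon, three bonds along the chain from an amide-type nitrogen in a ring.

Going by the values given here, with no measured step between compounds sharing this change, no step beyond the scatter is expected in this assay in either direction, so the value of compound 3 is estimated near that of compound 2. Compound 3 is estimated at 100 mg/kg, within 50 mg/kg to 200 mg/kg, an expected step of no change at the digits printed from compound 2 to compound 3 (within the scatter).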

Compound 3, dose for half-maximal effect: 100 mg/kg
The estimate for compound 3 equals the measured number at the digits printed, and the stated range covers the measured number.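

In this assay, the series now has its first measured step, which reads no change at the digits printed from compound 2 to compound 3 (within the scatter). For the compounds shown here, this is the first reading at this position, on a saturated chain carbon, three bonds along the chain from an amide-type nitrogen in a ring: with a group of 3 heavy atoms in place of a group of 4 heavy atoms and the shared core kept, the two values lie within the scatter of each other, so this one change in chain length separates nothing in this read-out. Compound 1 stays at a limit of the assay, which is not a number, and it differs from the other compounds in more than one place, so it gives no step to set beside this one: the limit of > 100 mg/kg in this assay, at which 1 of the 3 values shown sits.

Going by these compounds alone, whether the same reading would hold for a longer chain, or for a shorter chain on the core of compound 3, remains open, since a single step covers only this pair. Also open, as far as these compounds go, is how this assay would respond to an amine or a carboxylic acid at the end of the chain in place of the thioamide-bearing end, and whether any such group would give a value clearly apart from those of compound 2 and compound 3.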